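A few compounds are considered here, and "the series" means these few. Any claim that something is new, unique, unknown or untested is made for them only; others in the source may bear on it.

Working notes on the series. Compound 2 `Nc1cc(Oc2ccc(NC(=O)Nc3cccc(C(F)(F)F)c3)cc2)ncn1` carries an amino group on the shared core; in an assay on isolated protein for inhibition of serine/threonine-protein kinase TNNI3K (Homo sapiens) (a higher number here means a weaker inhibitor, a lower number a stronger inhibitor), compound 2 gives 25 nM. Compound 1 `CNc1cc(Oc2ccc(NC(=O)Nc3cccc(C(F)F)c3)cc2)ncn1` has methylamino at that place, and in this assay compound 1 gives 100 nM, a number beyond the scatter above that of compound 2. Compound 2 therefore stands lowest of the two numbers shown. Compound 3 `CCc1cc(NC(=O)Nc2cccc(C(F)(F)F)c2)cc(Cl)c1Oc1cc(NC)ncn1` differs from both at several places at once. In this assay compound 3 gives <= 10 nM, which is a limit of the assay and not a number; this is the limit of <= 10 nM in this assay, at which 1 of the 3 values shown sits. Compound 4 `O=C(Nc1ccc(Oc2ccncn2)cc1)Nc1cccc(C(F)(F)F)c1` is not yet measured. The change from compound 2 to compound 4 is hydrogen in place of amino on an aromatic carbon. Among the measured compounds shown here, no measured pair differs in just this way, so no measured step sets the size. Compound 1 with 100 nM shows that altering this group can weaken inhibition. The expected step is a 6.0-fold higher number from compound 2 to compound 4 (0.78 log units; beyond the scatter), toward a weaker inhibitor, beyond the scatter. For compound 4 the estimate in this assay is 150 nM, with a range from 40 nM to 600 nM.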

Compound 4, half-maximal inhibitory concentration: 160 nM
For compound 4 the middle estimate is 1.1-fold (0.03 log units) below the measured one; the range from low to high includes it.
By their numbers in this assay, from the lowest: compound 2; then compounds 1 and 4 (each within the scatter of the next). At a limit, below all of these: compound 3.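

Among the compounds shown here, this is the first change that can be read in one place: in this assay, hydrogen in place of amino on the aromatic carbon gives a 6.4-fold higher number from compound 2 to compound 4 (0.81 log units; beyond the scatter). For the compounds shown here, the same difference reads as 6-aminopyrimidin-4-yl to pyrimidin-4-yl, so the amino group counts towards the inhibition seen with compound 2, which the earlier compounds, differing in more than one place, could not show. No measurement shown gives a cause for this step.

Methylamino is not separated from the other change in compound 1, so its standing relative to amino and hydrogen stays open, as do a hydroxyl, a methoxy and a dimethylamino group at this place. Compound 3 gives <= 10 nM, a limit of the assay and not a number, and it differs from compound 2 in several places at once, so no single change can be read from it.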